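The source may hold more compounds than are shown below. What is called first, only, known or untested is meant among the compounds shown, and "the series" means these compounds.

Measured in a functional assay on BHK cells for positive allosteric modulation of metabotropic glutamate receptor 5 (Homo sapiens), read by FLIPR and calcium flux (on this read-out lower numbers stand for an effect already at smaller amounts and higher numbers for an effect only at larger amounts of compound), so far:
- compound 1 `NC(=O)c1ccc(C#Cc2ccccc2)nc1`: 6600 nM
- compound 2 `CC(C)CCNC(=O)c1ccc(C#Cc2ccccc2)nc1`: 510 nM

On these two numbers compound 2 holds the lowest value in this assay; the nearest number is that of compound 1, and the step between them, a 13-fold lower number from compound 1 to compound 2 (1.11 log units; beyond the scatter), lies beyond the scatter.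

Compound 3 `O=C(NC1CCCC1)c1ccc(C#Cc2ccccc2)nc1` differs from compound 2 in one place: cyclopentyl in place of isopentyl on an amide-type nitrogen. Within the data shown here, only one measured step exists, a 13-fold lower number from compound 1 to compound 2 (1.11 log units; beyond the scatter), and it compares an unsubstituted amide nitrogen with the isopentyl amide; it says nothing direct about exchanging one five-carbon substituent for another of the same size. The step from compound 2 to compound 3 keeps the substituted amide that distinguishes compound 2 from compound 1, so the large gain seen there is expected to be retained rather than lost. With no measured comparison between a chain and a ring at this position, the step of a 1.1-fold lower number from compound 2 to compound 3 (0.05 log units; within the scatter) is expected to stay within the scatter. Compound 3 is therefore estimated at 450 nM in this assay, with a range of 120 nM to 1800 nM.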

Compound 3, half-maximal effective concentration: 30 nM
Beside the measured number, compound 3's estimate is 15-fold (1.18 log units) above it, and the stated range ends above it.
By their numbers in this assay, from the lowest: compound 3; then compound 2; then compound 1.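

In this assay, isopentyl and cyclopentyl on the amide-type nitrogen both hold 5 heavy atoms, all carbon, and the one counted difference is the five-membered non-aromatic ring of cyclopentyl, yet the exchange gives a 17-fold lower number from compound 2 to compound 3 (1.23 log units; beyond the scatter). Filling the amide-type nitrogen with a carbon group is therefore not the whole story at this place: the form of the group also counts, a step as large as the earlier gain from hydrogen to isopentyl, and the total change from the unsubstituted amide reaches a 220-fold lower number from compound 1 to compound 3 (2.34 log units; beyond the scatter). No measurement on hand accounts for the difference between the chain and the ring at this place.

Open, as far as these compounds go, is whether the low number belongs to rings on this nitrogen in general or to the five-membered ring in particular, a question that cyclobutyl and cyclohexyl would address. Also open, from the compounds shown here alone, is whether a ring carrying oxygen, such as tetrahydrofuranyl, or a branched chain of similar size, such as 3-pentyl, would hold the number of compound 3 or fall back towards that of compound 2.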